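This account rests on a few compounds, and the source may have more. Where it says the series, first, only, none or still open, it means among the compounds named here.

Working notes on a small benzimidazole-linked series read in an ADME assay on HEp-2 cells (Homo sapiens) for cytotoxicity; a lower number here means that less compound is tolerated, a higher number that more compound is tolerated.

Of the compounds shown here, three carry numbers so far. Compound 1, `CC(C)CCn1c(Cn2c(=O)n(C(C)C)c3ccccc32)nc2cc(CNC3CC3)ccc21`, gives 17200 nM in this assay. Compound 2, `COC(=O)c1cccc2c1nc(Cn1c(=O)n(C(C)C)c3ccccc31)n2CCC(C)C`, gives 49200 nM, and compound 3, `C=C(C)n1c(=O)n(Cc2nc3cc(C#N)ccc3n2CCC(C)C)c2ccccc21`, gives 1480 nM. Among these three, compound 1 stands second highest: the nearest number is that of compound 2, which lies higher by a margin beyond the usual scatter, and the furthest is that of compound 3, which lies lower, also beyond the scatter. Going by the values given here, no two of the measured compounds differ in a single place, so no step between them can be read directly.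

The next compound in line is compound 4, `CC(C)CCn1c(Cn2c(=O)n(C(C)C)c3ccccc32)nc2cc(C(N)=O)ccc21`, which is derived from compound 1 by one change: carbamoyl in place of (cyclopropylamino)methyl on an aromatic carbon. The rest of the shared core is untouched.

With no measured step for this kind of change, the expectation rests on the spread of the three numbers shown. For compound 4 a step from compound 1 of a 1.9-fold higher number from compound 1 to compound 4 (0.27 log units; within the scatter) in this assay is expected, upward, of a size that would reach beyond the scatter. Compound 4 is estimated at 32000 nM, with a range from 12000 nM to 80000 nM.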

Compound 4, half-maximal cytotoxic concentration: 23400 nM
Compound 4: the middle estimate sits 1.4-fold (0.14 log units) above what was measured; the range from low to high includes it.
By their numbers in this assay, from the lowest: compound 3; then compounds 1 and 4 (each within the scatter of the next); then compound 2.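

The step of a 1.4-fold higher number from compound 1 to compound 4 (0.13 log units; within the scatter) in this assay lies within the scatter, so at this aromatic carbon, meta to one fused ring and para to the other as printed for the change, carbamoyl and (cyclopropylamino)methyl cannot be told apart. The exchange removes the three-membered ring of carbon only and brings in a double bond outside aromatic rings, while the hydrogen-bond donor and acceptor counts match and neither group carries a net charge, and this difference in make-up leaves no reading beyond the scatter in this series. No measurement at hand bears on why the two groups give values within the scatter of each other.

From the compounds shown here alone, whether a carboxylic acid, a plain aminomethyl or a longer chain on the same aromatic carbon would also stay within the scatter of compound 1 remains open. Compound 2 and compound 3 each differ from compound 1 and compound 4 in more than one place, so steps to them cannot be read, and the shown compounds do not settle which part of the structure governs the spread of values in this series.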